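Indole for Bromophenyl in a Second Sulfur-Linked Series

The compounds below may be only part of what the source reports. "The series", "measured", "known", "first", "only" and "open" are said of these compounds alone.

Measured compounds:
compound 1, `Cc1ccc(CS(=O)(=O)/C(=C/c2ccc(Br)cc2)C(=O)c2ccc(Cl)cc2)cc1`, 25000 nM
compound 2, `Cc1ccc(CS(=O)(=O)/C(=C/c2c[nH]c3ccc(Br)cc23)C(=O)c2ccc(Cl)cc2)cc1`, 10000 nM
compound 3, `O=C(/C(=C\c1ccc(Br)cc1)SCc1ccc(F)cc1)c1ccc(Cl)cc1`, 9000 nM

All three were tested in a functional assay on DU-145 cells (Homo sapiens) for inhibition, read by trypan blue exclusion, with a stated time of 96 h; on this read-out lower numbers stand for stronger inhibition of growth and higher numbers for weaker inhibition of growth. Compound 1 and compound 2 share a core and differ in one place, (5-bromo-1H-indol-3-yl in place of 4-bromophenyl on a double-bonded chain carbon bound to a double-bonded chain carbon), and the number moved a 2.5-fold lower number from compound 1 to compound 2 (0.40 log units; beyond the scatter). Compound 3 has a different core; how the core of compound 1 and the core of compound 3 differ is not broken down here. Compound 3 and compound 2 give numbers within the usual scatter of each other, so no order between them can be read.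

Compound 4, `O=C(/C(=C\c1c[nH]c2ccc(Br)cc12)SCc1ccc(F)cc1)c1ccc(Cl)cc1`, has not yet been measured. It is made from compound 3 by 5-bromo-1H-indol-3-yl in place of 4-bromophenyl on a double-bonded chain carbon bound to a double-bonded chain carbon, the same change that led from compound 1 to compound 2, at the same place. Because compound 3 gives 9000 nM and the earlier step was a 2.5-fold lower number from compound 1 to compound 2 (0.40 log units; beyond the scatter), a step of similar size is expected here, a 2.3-fold lower number from compound 3 to compound 4 (0.35 log units; beyond the scatter). This rests on one earlier pair alone. Compound 4 is therefore estimated at 4000 nM, between 1800 nM and 9000 nM.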

Compound 4, concentration for 50% growth inhibition: 50000 nM
The estimate for compound 4 lay 13-fold (1.10 log units) below the measured number, and the stated range ends below it.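

On the core of compound 3, the change from 4-bromophenyl to 5-bromo-1H-indol-3-yl did not repeat its earlier effect in this assay, giving instead a 5.6-fold higher number from compound 3 to compound 4 (0.74 log units; beyond the scatter), a shift opposite in direction to the first step. The effect of this change therefore depends on the core that carries it, and a result from one core cannot safely be carried over to the other: the same change on two cores in this assay, a 2.5-fold lower number (0.40 log units; beyond the scatter) from compound 1 to compound 2 and a 5.6-fold higher number (0.74 log units; beyond the scatter) from compound 3 to compound 4, 14-fold (1.14 log units) apart, beyond the scatter of two such steps. This does not show which feature of the two cores is responsible, and with a single pair on each core, it does not show how the change would behave on any further core.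

The compounds shown leave open whether 5-bromo-1H-indol-3-yl would give a similar result with a methyl group on its nitrogen, which would remove its hydrogen-bond donor. They also leave open what an amine or a carboxylic acid in place of the bromine would do on either core.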